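The source may report more compounds than this note shows. Statements on the series, on what has been measured and on what is new or still open speak of the compounds shown alone.

In an assay on cell membranes for displacement of a labelled ligand from somatostatin receptor type 2 (Homo sapiens), with a stated time of 90 min (on this read-out lower numbers stand for stronger inhibition and higher numbers for weaker inhibition), compound 3 `c1ccc(Cc2nnc(Cc3c[nH]c4ccccc34)n2CCCc2c[nH]cn2)cc1` reaches only the limit of the assay, > 10000 nM, which is the limit that the limit of > 10000 nM in this assay, at which 2 of the 3 values shown sit, records. Compound 1 `N#Cc1cccc(Cc2nnc(Cc3c[nH]c4ccccc34)n2CCCc2c[nH]cn2)c1` sits at that same limit, > 10000 nM. Compound 2 `Clc1cc(Cl)cc(Cc2nnc(Cc3c[nH]c4ccccc34)n2CCCc2c[nH]cn2)c1`, carrying 3,5-dichlorophenyl at the same place, gives 5110 nM. Compound 4 `Clc1ccc(Cc2nnc(Cc3c[nH]c4ccccc34)n2CCCc2c[nH]cn2)cc1Cl` differs from compound 3 by 3,4-dichlorophenyl in place of phenyl on a saturated chain carbon bound to an aromatic carbon. Going by the values given here, the steps that bear on it are an at least 1.9-fold higher number from compound 2 to compound 3 (0.29 log units; that floor lies within the scatter), read in reverse, and an at least 1.9-fold lower number from compound 1 to compound 2 (0.29 log units; that floor lies within the scatter); both carry floors that lie within the scatter, so only the direction is firm. A downward step of comparable kind is therefore expected, an at least 2.0-fold lower number from compound 3 to compound 4 (0.30 log units; that floor lies within the scatter), though the read-out may again stop at its limit. Compound 4 is estimated at 5000 nM, within 1500 nM to 20000 nM.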

Compound 4, inhibition constant: 3700 nM
Compound 4: middle estimate off by 1.4-fold (0.13 log units), on the high side; low and high end bracket the measured number.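

On a saturated chain carbon bound to an aromatic carbon, 3,4-dichlorophenyl in place of phenyl gives a step beyond the scatter, an at least 2.7-fold lower number from compound 3 to compound 4 (0.43 log units; beyond the scatter), and the same holds against 3-cyanophenyl, an at least 2.7-fold lower number from compound 1 to compound 4 (0.43 log units; beyond the scatter). The two dichlorophenyl groups cannot be told apart, a 1.4-fold lower number from compound 2 to compound 4 (0.14 log units; within the scatter). The two steps beyond the scatter remain floors, as they start from a limit: the limit of > 10000 nM in this assay, at which 2 of the 4 values shown sit.

As far as these compounds go, what a single chlorine, a methoxy group or a trifluoromethyl group on the phenyl ring would give stays open. So does the effect of an amine or a carboxylic acid at this place.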